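From chloromethyl to vinyl on a carbonyl carbon

The source may report more compounds than this note shows. Statements on the series, on what has been measured and on what is new or still open speak of the compounds shown alone.

Compound 1 (`CCOC(=O)c1csc2nc(-c3ccc(NC(=O)Nc4ccc(Br)cn4)cc3)cn12`), compound 2 (`CCCS(=O)(=O)Nc1ccc(-c2cn3c(C(=O)OCC)csc3n2)cc1`) and compound 3 (`CCOC(=O)c1csc2nc(-c3ccc(NC(=O)CCl)cc3)cn12`) keep the shared core and differ in the group on a nitrogen on an aromatic ring. In a functional assay on HeLa cells (Homo sapiens) for cytotoxicity, read by MTT assay, with a stated time of 72 h (a lower number here means a stronger inhibitor, a higher number a weaker inhibitor), compound 1 gives > 20000 nM, which is a limit. In this assay compound 2 gives > 20000 nM, also a limit. In this assay compound 3 gives > 20000 nM, again a limit and not a number. Among the compounds with values here, compound 3 therefore has no measured potency to start from, and the series so far stands at the limit of > 20000 nM in this assay, at which 3 of the 3 values shown sit.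

Compound 4 (`C=CC(=O)Nc1ccc(-c2cn3c(C(=O)OCC)csc3n2)cc1`) has vinyl in place of chloromethyl on a carbonyl carbon, whose other neighbour is an amide-type nitrogen: vinyl in place of chloromethyl on a carbonyl carbon.

The closest measured changes are a step that the two limits leave unreadable from compound 1 to compound 3 and a step that the two limits leave unreadable from compound 2 to compound 3, and the remaining one is a step that the two limits leave unreadable from compound 1 to compound 2. None of the three gives a size to carry over, so no direction can be set for this change in this assay. The working expectation is simply that compound 4 stays near the limit reached by the other three. The expected change is a number no higher from compound 3 to compound 4 (the limit leaves the size open). The estimate for compound 4 is 20000 nM, with an expected range from 8000 nM to 40000 nM.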

Compound 4, half-maximal inhibitory concentration: > 20000 nM
Compound 4 gave a limit, no number; the forecaster's own chance of this, stated with the estimate: 75%; the middle value lies on the limit itself.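

In this assay, within the data shown here, compound 4 gives > 20000 nM as a limit and not a number, so no step from compound 1, compound 2 or compound 3 to compound 4 can be read. The compounds shown leave open what potency any of them has in this assay and whether the group on the nitrogen alters it: the limit of > 20000 nM in this assay, at which 4 of the 4 values shown sit.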